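Swapping Cyclohexyl for Phenyl on the Shared Core

This account rests on a few compounds, and the source may have more. Where it says the series, first, only, none or still open, it means among the compounds named here.

Compound 1 `O=C(NCc1cnc2scc(-c3ccc(Br)cc3)n12)NC1CCCCC1`: 1800 nM in an assay on isolated protein for inhibition of Indoleamine 2,3-dioxygenase 1 (Homo sapiens), with a stated time of 30 min; a lower number here means a stronger inhibitor, a higher number a weaker inhibitor.
Compound 2 `CCOC(=O)c1cnc2scc(-c3cccc(C)c3)n12`: > 100000 nM, which is a limit of the assay rather than a number.
Compound 3 `CCOC(=O)c1cnc2scc(-c3ccccc3C)n12`: > 100000 nM, which is likewise a limit rather than a number.

Of the three measured compounds, compound 1 is the only one for which this assay returns a number at all. Compound 2 and compound 3 both sit at the limit of > 100000 nM in this assay, at which 2 of the 3 values shown sit. Going by the values given here, those two compounds differ from compound 1 in more than one place, so they offer no measured step in the direction studied here, and nothing can be drawn from them about it.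

Compound 4 `O=C(NCc1cnc2scc(-c3ccc(Br)cc3)n12)Nc1ccccc1` has not yet been measured. It differs from compound 1 in a single place: phenyl in place of cyclohexyl on an amide-type nitrogen. Among the compounds with values here, no pair of measured compounds differs in just this place, so there is no measured step to lean on. Exchanging one six-membered ring of carbon for another on an amide-type nitrogen is expected to move this assay only modestly, most likely within or just beyond the usual scatter, and in no firmly predictable direction. The step from compound 1 to compound 4 is expected to be a 1.2-fold lower number from compound 1 to compound 4 (0.08 log units; within the scatter). Compound 4 is therefore estimated at 1500 nM, with a range from 400 nM to 6000 nM.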

Compound 4, half-maximal inhibitory concentration: 220 nM
Compound 4: the middle estimate sits 6.8-fold (0.83 log units) above what was measured, and the stated range ends above it.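

In this assay, going by these compounds alone, the group on the amide-type nitrogen clearly matters: phenyl in place of cyclohexyl gives an 8.2-fold lower number from compound 1 to compound 4 (0.91 log units; beyond the scatter), the first measured step at this position. The change is a narrow one, since both groups are six-membered rings with the same count of heavy atoms, all of them carbon, and neither adds a hydrogen-bond donor or acceptor; what differs is that phenyl is aromatic and cyclohexyl is not, so rings that look alike by these counts are not interchangeable here. This is a single pair of compounds, however, and nothing measured here explains why the number falls.

Going by these compounds, it remains open whether any aromatic ring on this nitrogen would give a similar result, or whether this depends on phenyl itself, as a comparison with pyridyl, benzyl or a phenyl ring carrying a fluorine or a methoxy group could show. A single step also cannot tell whether the same exchange would have a similar size with other groups elsewhere on the shared core.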